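Trimming the dioxolane side chain of compound 2

The compounds below may be only part of what the source reports. "The series", "measured", "known", "first", "only" and "open" are said of these compounds alone.

Three compounds share one core and differ only in the chain on the aromatic nitrogen. Compound 1 `CN1CCN(CCCCCn2c3c(c4ccccc42)C(=O)c2c[n+]([O-])c4ccccc4c2C3=O)CC1` gives 1710 nM in a functional assay on A-375 cells (Homo sapiens) for cytotoxicity, read by MTT assay, with a stated time of 72 h; a lower number here means a stronger inhibitor, a higher number a weaker inhibitor; compound 3 `CN(C)CCCCn1c2c(c3ccccc31)C(=O)c1c[n+]([O-])c3ccccc3c1C2=O` gives 470 nM; and compound 2 `CC1(C)O[C@@H](CO)[C@H](Cn2cc(Cn3c4c(c5ccccc53)C(=O)c3c[n+]([O-])c5ccccc5c3C4=O)nn2)O1` gives 190 nM, the lowest of the three numbers. Among the compounds with values here, the only measured step, a 3.6-fold lower number from compound 1 to compound 3 (0.56 log units; beyond the scatter), concerns the amine end of a saturated chain and says nothing about the dioxolane of compound 2.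

Compound 4 `CC1(C)OC[C@@H](Cn2cc(Cn3c4c(c5ccccc53)C(=O)c3c[n+]([O-])c5ccccc5c3C4=O)nn2)O1` has not yet been measured. It differs from compound 2 by 2,2-dimethyl-1,3-dioxolan-4-yl in place of 5-(hydroxymethyl)-2,2-dimethyl-1,3-dioxolan-4-yl on a saturated chain carbon bound to an aromatic nitrogen. Within the data shown here, no measured pair shows what removing this piece does, so the expectation rests on the change being small in size and far from the amine chain where the one known step lies. Compound 4 is therefore expected to sit close to compound 2, with a step of a 1.5-fold higher number from compound 2 to compound 4 (0.17 log units; within the scatter) that may not clear the scatter. The estimate for compound 4 in this assay is 280 nM, with a range from 120 nM to 700 nM.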

Compound 4, half-maximal inhibitory concentration: 450 nM
For compound 4 the middle estimate is 1.6-fold (0.21 log units) below the measured one; low and high end bracket the measured number.
By their numbers in this assay, from the lowest: compound 2; then compounds 4 and 3 (each within the scatter of the next); then compound 1.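

In this assay, the dioxolane end of the chain now has a measured step of its own, a 2.4-fold higher number from compound 2 to compound 4 (0.37 log units; beyond the scatter), as 5-(hydroxymethyl)-2,2-dimethyl-1,3-dioxolan-4-yl gives way to 2,2-dimethyl-1,3-dioxolan-4-yl. Within the data shown here, the step is modest, yet it shows that this position is not indifferent to losing the hydroxymethyl group, which the one earlier step, confined to the amine end of a saturated chain, could not show. No available evidence explains why the number rises with this change.

The compounds shown leave open whether the hydroxyl alone or the whole hydroxymethyl group accounts for the step, as a methyl, methoxymethyl or aminomethyl group in its place is not among them. Also open, from the compounds shown here alone, is what a diol would give in place of the dioxolane ring.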